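Working notes: phenyl in place of cycloheptyl

A few compounds are considered here, and "the series" means these few. Any claim that something is new, unique, unknown or untested is made for them only; others in the source may bear on it.

Measured in a functional assay on HT-29 cells (Homo sapiens) for inhibition, read by sulforhodamine B assay, with a stated time of 48 h; on this read-out lower numbers stand for stronger inhibition of growth and higher numbers for weaker inhibition of growth:
- compound 1 `c1ccc(Oc2ccc(NC3=NCCO3)cc2)cc1`: 2000 nM
- compound 2 `O=C(CCl)NC(=O)Nc1ccc(OC2CCCCCC2)cc1`: 2300 nM

The value of compound 2 lies within the usual scatter of the value of compound 1, so the two set no order. Compound 3 `O=C(CCl)NC(=O)Nc1ccc(Oc2ccccc2)cc1` has phenyl in place of cycloheptyl on an oxygen on an aromatic ring. Going by the values given here, no measured pair shows this change directly. Compound 1, on a different core, also has phenyl on an oxygen on an aromatic ring and gives 2000 nM. In this assay, no direction is favoured, and the expected step is no change at the digits printed from compound 2 to compound 3 (within the scatter), none beyond the scatter. For compound 3 the estimated value is 2300 nM, with an expected range of 800 nM to 6500 nM.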

Compound 3, concentration for 50% growth inhibition: 3600 nM
Beside the measured number, compound 3's estimate is 1.6-fold (0.19 log units) below it; measured number inside the range.
By their numbers in this assay, from the lowest: compounds 1, 2 and 3 (each within the scatter of the next).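

In this assay, phenyl in place of cycloheptyl on an oxygen on an aromatic ring gives a 1.6-fold higher number from compound 2 to compound 3 (0.19 log units; within the scatter) and so sets no order between these two groups at this position. On a nitrogen on an aromatic ring, the open-chain group in place of the group with a five-membered non-aromatic ring gives a 1.8-fold higher number from compound 1 to compound 3 (0.26 log units; within the scatter) and likewise sets no order. No measured property bears on either step. Going by these compounds, whether a methyl group or a longer alkyl chain on that oxygen would give a step beyond the scatter remains open.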